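A few compounds are considered here, and "the series" means these few. Any claim that something is new, unique, unknown or untested is made for them only; others in the source may bear on it.

Measured compounds:
Compound 1 `CCCCCCc1cc2cn([C@H]3C[C@H](O)[C@@H](CO)O3)c(=O)nc2o1` gives > 50000 nM in a functional assay on HEL cells (Homo sapiens) for cytotoxicity, read by microscopy (on this read-out lower numbers stand for higher toxicity in this test and higher numbers for lower toxicity in this test), a limit of the assay and not a number.
Compound 2 `CCCCCCCc1cc2cn([C@H]3C[C@H](O)[C@@H](CO)O3)c(=O)nc2o1` gives > 50000 nM in this assay, again a limit.

Both measured values sit at the limit of > 50000 nM in this assay, at which 2 of the 2 values shown sit. The step that the two limits leave unreadable from compound 1 to compound 2 accordingly cannot be read in either size or direction. Compound 3 `CCCCCCCCc1cc2cn([C@H]3C[C@H](O)[C@@H](CO)O3)c(=O)nc2o1` carries the next change of the same kind, (methyl in place of hydrogen on a saturated chain carbon, seven bonds along the chain from an aromatic carbon). Among the compounds with values here, the only measured step bearing on this change is a step that the two limits leave unreadable from compound 1 to compound 2, and since it is unreadable, no size of step in this assay can be derived from it; nothing beyond a further limit is expected. For compound 3 the expected step is a number no higher from compound 2 to compound 3 (the limit leaves the size open), meaning no readable change. Compound 3 is expected to give 50000 nM in this assay, with a range from 25000 nM to 100000 nM, and most probably the result will again be reported only as a limit.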

Compound 3, minimum cytotoxic concentration: > 50000 nM
Compound 3 was reported as a limit; the forecaster's own chance of this, stated with the estimate: 85%; the middle value sits exactly at the limit.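

In this assay no step can be read among compound 1, compound 2 and compound 3, because all three values are limits of the assay and not numbers: the limit of > 50000 nM in this assay, at which 3 of the 3 values shown sit.

The compounds shown leave open whether the longer chain on the shared core changes the read-out in this assay at all.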